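The source may report more compounds than this note shows. Statements on the series, on what has been measured and on what is new or still open speak of the compounds shown alone.

Measured so far in a functional assay on MDA-MB-231 cells (Homo sapiens) for inhibition, read by sulforhodamine B assay, with a stated time of 48 h, tested at 10 uM; a lower number here means less inhibition, a higher number more inhibition at the concentration tested (going by the name of the read-out):
- compound 1 `Brc1cn2ccnc2c(-c2ccc3ncn(C4CCCCC4)c3c2)n1` gives 24.2%
- compound 2 `COc1ccc(-c2cn3ccnc3c(-c3ccc4ncn(C5CCCCC5)c4c3)n2)cc1` gives 71.1%
- compound 3 `O=Cc1ccc(-c2cn3ccnc3c(-c3ccc4ncn(C5CCCCC5)c4c3)n2)cc1` gives 51.2%

Compound 3 stands second highest of the three: below compound 2, as the step of a number 19.9 percentage points lower from compound 2 to compound 3 (beyond the scatter) shows, and above compound 1, as the step of a number 27 percentage points higher from compound 1 to compound 3 (beyond the scatter) shows.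

Compound 4 `c1cn2cc(-c3ccsc3)nc(-c3ccc4ncn(C5CCCCC5)c4c3)c2n1` differs from compound 3 in one place: thiophen-3-yl in place of 4-formylphenyl on an aromatic carbon.

Among the compounds with values here, two steps bear on this. Replacing bromo with an aromatic ring gave a number 46.9 percentage points higher from compound 1 to compound 2 (beyond the scatter) and a number 27 percentage points higher from compound 1 to compound 3 (beyond the scatter), so an aromatic ring at this place matters. Swapping the group on that ring gave only a number 19.9 percentage points lower from compound 2 to compound 3 (beyond the scatter). Compound 4 keeps an aromatic ring, so the expected step of a number 3.2 percentage points lower from compound 3 to compound 4 (within the scatter) is within the scatter or slightly downward. Compound 4 is therefore estimated at 48%, between 25% and 72%.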

Compound 4, a percentage reported as inhibition, at one concentration (the size of the read-out at that concentration, not a potency): 1.35%
Beside the measured number, compound 4's estimate is 46.7 percentage points above it, outside the stated range (below it).
By their numbers in this assay, from the lowest: compound 4; then compound 1; then compound 3; then compound 2.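

Keeping an aromatic ring at this position is not enough to keep the inhibition: thiophen-3-yl gives a number 49.9 percentage points lower from compound 3 to compound 4 (beyond the scatter) and a number 69.8 percentage points lower from compound 2 to compound 4 (beyond the scatter). It even falls short of bromo, with a number 22.9 percentage points lower from compound 1 to compound 4 (beyond the scatter), so in this assay the gain seen earlier belongs to the two substituted six-membered rings, not to any aromatic ring. Nothing available here explains this drop.

Still open, as far as these compounds go, is whether an unsubstituted phenyl ring or thiophen-2-yl would restore inhibition. It is also unknown how a phenyl ring carrying an amine or a carboxylic acid would compare.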